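Fluoro for trifluoromethyl on the benzyl ether of compound 1

A few compounds are considered here, and "the series" means these few. Any claim that something is new, unique, unknown or untested is made for them only; others in the source may bear on it.

Among the measured compounds shown here, compound 1 `O=c1cc(Cn2ccnc2)c2ccc(OCc3cccc(C(F)(F)F)c3)cc2o1` is tested in an assay on V79MZh11B2 cells for inhibition of cytochrome P450 11B2, mitochondrial (Homo sapiens), read by HPLC, with a stated time of 25 min; a lower number here means a stronger inhibitor, a higher number a weaker inhibitor; in this assay compound 1 gives 150 nM, the highest of the two numbers so far. Compound 2 `COc1cccc(COc2ccc3c(Cn4ccnc4)cc(=O)oc3c2)c1` gives 127 nM, and the change from compound 1 to compound 2 is a 1.2-fold lower number from compound 1 to compound 2 (0.07 log units; within the scatter). Compound 3 `O=c1cc(Cn2ccnc2)c2ccc(OCc3cccc(F)c3)cc2o1` differs from compound 1 by fluoro in place of trifluoromethyl on an aromatic carbon. For the measured compounds named here, the only step that bears on it, the swap at the same aromatic carbon from compound 1 to compound 2, stayed within the scatter, so no step beyond the scatter is expected in this assay. Compound 3 is estimated at 150 nM, with a range from 70 nM to 330 nM, corresponding to no change at the digits printed from compound 1 to compound 3 (within the scatter) as the expected step.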

Compound 3, half-maximal inhibitory concentration: 200 nM
Compound 3: the middle estimate sits 1.3-fold (0.12 log units) below what was measured; the measured number falls inside the stated range.
By their numbers in this assay, from the lowest: compounds 2, 1 and 3 (each within the scatter of the next).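

At this aromatic carbon, fluoro now stands with trifluoromethyl and methoxy, and in this assay all three lie within the scatter of one another (a 1.3-fold higher number from compound 1 to compound 3 (0.12 log units; within the scatter)) and (a 1.6-fold higher number from compound 2 to compound 3 (0.20 log units; within the scatter)). Going from the 4 heavy atoms of trifluoromethyl to the 1 heavy atom of fluoro therefore gives no resolved change across these compounds. Nothing measured here accounts for this flat result.

From the compounds shown here alone, whether an amine, a carboxylic acid or a longer chain at this carbon would move the number beyond the scatter remains open. So does the effect of a plain hydrogen there.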